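Swapping a halogenated ring for a dihydroxyphenyl ring

The compounds below may be only part of what the source reports. "The series", "measured", "known", "first", "only" and "open" are said of these compounds alone.

Of the compounds shown here, three sharing one core have been measured so far. Compound 1 `CN(C)CCn1cnnc1-c1cc(Oc2ccc(NC(=O)N/N=C/c3cccc(Br)c3)cc2F)ccn1` gives 970 nM in a functional assay on A549 cells (Homo sapiens) for cytotoxicity, read by MTT assay, with a stated time of 72 h; on this read-out higher numbers stand for weaker inhibition and lower numbers for stronger inhibition. Compound 2 `CN(C)CCn1cnnc1-c1cc(Oc2ccc(NC(=O)N/N=C/c3ccc(F)cc3Cl)cc2F)ccn1` gives 1120 nM in this assay, and compound 3 `CN(C)CCn1cnnc1-c1cc(Oc2ccc(NC(=O)N/N=C/c3cccc(Cl)c3Cl)cc2F)ccn1` gives 1090 nM in this assay. Compound 2 has the highest of the three numbers as they stand, but the steps to its neighbours are tiny: a 1.2-fold higher number from compound 1 to compound 2 (0.06 log units; within the scatter) and a 1.0-fold lower number from compound 2 to compound 3 (0.01 log units; within the scatter), both within the scatter, so these three compounds cannot be told apart on this evidence.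

Compound 4 `CN(C)CCn1cnnc1-c1cc(Oc2ccc(NC(=O)N/N=C/c3ccc(O)c(O)c3)cc2F)ccn1` has not yet been measured. It differs from compound 2 at one place: 3,4-dihydroxyphenyl in place of 2-chloro-4-fluorophenyl on a carbon with a double bond to nitrogen. The measured steps all exchange one halogen-bearing ring for another at the same carbon, a 1.1-fold higher number from compound 1 to compound 3 (0.05 log units; within the scatter) included, and none of them reaches beyond the scatter. None of them brings in hydroxyl groups, so they offer no direct guide to this change; they show only that three different halogen patterns on this ring left the number unchanged. The expected step is therefore modest and uncertain, a 1.3-fold higher number from compound 2 to compound 4 (0.13 log units; within the scatter). Compound 4 is estimated at 1500 nM, with a range from 600 nM to 4000 nM.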

Compound 4, half-maximal inhibitory concentration: > 100000 nM
Compound 4: only a limit was reported (the forecaster's own chance of this, stated with the estimate: 5%); middle value at least 66-fold (1.82 log units) from the limit.
By their numbers in this assay, from the lowest: compounds 1, 3 and 2 (each within the scatter of the next). At a limit, above all of these: compound 4.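

Compound 4 gives only a limit in this assay, not a number: the limit of > 100000 nM in this assay, at which 1 of the 4 values shown sits.

Even so, the steps to it are large and lie beyond the scatter: an at least 89-fold higher number from compound 2 to compound 4 (1.95 log units; beyond the scatter), an at least 91-fold higher number from compound 3 to compound 4 (1.96 log units; beyond the scatter) and an at least 100-fold higher number from compound 1 to compound 4 (2.01 log units; beyond the scatter). The three halogen-bearing rings could not be told apart, which might suggest that this position tolerates change, but compound 4 shows that the ring on this carbon can decide whether any inhibition is seen in this assay at the concentrations reported.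

On these data alone, it remains open whether a ring with a single hydroxyl group, or with two methoxy groups in place of the hydroxyl groups, would behave like the halogen-bearing rings or like compound 4. The reason for the loss of inhibition also stays unknown, as no measurement shown speaks to it.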